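Compound 2 Loses Its Fluoro: An Expected Result

The source may report more compounds than this note shows. Statements on the series, on what has been measured and on what is new or still open speak of the compounds shown alone.

Measured in a functional assay on MCF7 cells (Homo sapiens) for antiproliferative activity, read by MTT assay, with a stated time of 72 h; a higher number here means a weaker inhibitor, a lower number a stronger inhibitor:
- compound 1 `O=C(N/N=C/c1ccc(F)cc1Cl)Nc1ccc(Oc2ccnc3[nH]ccc23)c(F)c1`: 7610 nM
- compound 2 `O=C(N/N=C/c1ccc(O)cc1)Nc1ccc(Oc2ccnc3[nH]ccc23)c(F)c1`: "not active" (no number reported)
- compound 3 `O=C(N/N=C/c1ccc(O)cc1O)Nc1ccc(Oc2ccnc3[nH]ccc23)c(F)c1`: 48000 nM

For the measured compounds named here, compound 2 has no number to stand on, so no step can start from it. Compound 4 `O=C(N/N=C/c1ccc(O)cc1)Nc1ccc(Oc2ccnc3[nH]ccc23)cc1` differs from compound 2 by hydrogen in place of fluoro on an aromatic carbon and carries hydrogen in place of fluoro on an aromatic carbon. Going by the values given here, no measured step covers this change. The only one, a 6.3-fold higher number from compound 1 to compound 3 (0.80 log units; beyond the scatter), was modest and concerns a different place. With compound 3 at 48000 nM and compound 2 reported as "not active" (no number reported) in the same assay, compound 4 is expected to stay weak, with no step beyond the scatter in either direction. In this assay the expected value of compound 4 is 40000 nM with an estimated range of 12000 nM to 100000 nM and it may again give no number.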

Compound 4, half-maximal inhibitory concentration: 5800 nM
For compound 4 the middle estimate is 6.9-fold (0.84 log units) above the measured one; the whole stated range lies above it.
By their numbers in this assay, from the lowest: compounds 4 and 1 (each within the scatter of the next); then compound 3.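

For the compounds shown here, compound 2 carries no number, so no step from it to compound 4, at 5800 nM, can be read. The compounds shown leave open what hydrogen in place of fluoro does here. Nothing measured explains this result.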